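The source may report more compounds than this note shows. Statements on the series, on what has been measured and on what is new or still open speak of the compounds shown alone.

In an assay on SK-BR-3 cells for inhibition of Aromatase (Homo sapiens) (on this read-out lower numbers stand for stronger inhibition and higher numbers for weaker inhibition), compound 2 `CN(c1ccc([N+](=O)[O-])cc1OC1CCCCC1)S(C)(=O)=O` gives 470 nM, the lowest of the two numbers in hand; compound 1 `CCCCCCCCCOc1cc([N+](=O)[O-])ccc1NS(C)(=O)=O` gives 910 nM, which lies within the scatter of that value. Compound 3 `CCC(CC)Oc1cc([N+](=O)[O-])ccc1N(C)S(C)(=O)=O` differs from compound 2 in one place: pentan-3-yl in place of cyclohexyl on an oxygen on an aromatic ring. Among the compounds with values here, no measured pair in this set shows a change of this kind, so there is nothing to set its size against. Because compound 2 gives 470 nM, the step is expected to stay within the scatter, amounting to a 1.3-fold higher number from compound 2 to compound 3 (0.11 log units; within the scatter). Compound 3 is therefore estimated at 600 nM, with a range from 250 nM to 1500 nM.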

Compound 3, half-maximal inhibitory concentration: 230 nM
For compound 3 the middle estimate is 2.6-fold (0.42 log units) above the measured one; the measured number lies below the stated range.
By their numbers in this assay, from the lowest: compound 3; then compounds 2 and 1 (each within the scatter of the next).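

With pentan-3-yl in place of cyclohexyl on an oxygen on an aromatic ring, this assay shows a 2.0-fold lower number from compound 2 to compound 3 (0.31 log units; beyond the scatter), a modest step. Within the data shown here, this is the first sign that the group at this position can shift the read-out, and compound 3 shows that a ring there is not needed to reach the lower number. Nothing in hand accounts for the step. This single pair cannot separate the loss of the ring from the change in size. On these data alone, how a cyclopentyl ring or a propan-2-yl group would read in this place remains open.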